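From 3,4-dimethylphenyl to phenyl on the amine nitrogen

The source may hold more compounds than are shown below. What is called first, only, known or untested is meant among the compounds shown, and "the series" means these compounds.

In a functional assay on ECa-109 cells for inhibition, with ECa-109 cell line (Homo sapiens) as the target, read by sulforhodamine B assay (on this read-out lower numbers stand for stronger inhibition and higher numbers for weaker inhibition), compound 1 `O=C1C=C(NC2CCCCC2)C(=O)c2c1nc1n2[C@H]2OC[C@@H](O)[C@H]2OC1` gives > 16000 nM, which is a limit and not a number. For the measured compounds named here, compound 2 `Cc1ccc(NC2=CC(=O)c3nc4n(c3C2=O)[C@H]2OC[C@@H](O)[C@H]2OC4)cc1C` gives 2820 nM, the only true number so far. Going by the values given here, the single measured step is an at least 5.6-fold lower number from compound 1 to compound 2 (0.75 log units; beyond the scatter), and its size is bounded by the limit of > 16000 nM in this assay, at which 1 of the 2 values shown sits. Compound 3 `O=C1C=C(Nc2ccccc2)C(=O)c2c1nc1n2[C@H]2OC[C@@H](O)[C@H]2OC1` has phenyl in place of 3,4-dimethylphenyl on an amine nitrogen. Among the compounds with values here, the aromatic ring stays, and no measured step tests this change directly. A small rise is expected, a 1.6-fold higher number from compound 2 to compound 3 (0.20 log units; within the scatter), possibly within the scatter. The estimated value for compound 3 is 4500 nM, with an expected range of 1800 nM to 12000 nM.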

Compound 3, half-maximal inhibitory concentration: 4970 nM
The estimate for compound 3 lay 1.1-fold (0.04 log units) below the measured number; low and high end bracket the measured number.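

On the amine nitrogen, phenyl and 3,4-dimethylphenyl are not separated in this assay by a 1.8-fold higher number from compound 2 to compound 3 (0.25 log units; within the scatter), so the two methyl groups are not needed to keep this level of inhibition. The advantage over cyclohexyl also holds with the plain phenyl ring, as an at least 3.2-fold lower number from compound 1 to compound 3 (0.50 log units; beyond the scatter) shows. As far as these compounds go, the true size of that step stays unknown because compound 1 sits at a limit: the limit of > 16000 nM in this assay, at which 1 of the 3 values shown sits.

Still open, from the compounds shown here alone, is whether a chloro or methoxy substituent on the phenyl ring, or a benzyl group on the amine nitrogen, would shift the number beyond the scatter.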